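This account rests on a few compounds, and the source may have more. Where it says the series, first, only, none or still open, it means among the compounds named here.

Measured so far:
- compound 1 `COc1cccc(/C=C2\CCc3cc(OC)c(OC)cc3C2=O)c1`: 5000 nM
- compound 2 `COc1cc2c(cc1OC)C(=O)/C(=C/c1cccc(C)c1)CC2`: 17000 nM
- compound 3 `COc1ccc(/C=C2\CCc3cc(OC)c(OC)cc3C2=O)cc1`: > 50000 nM (a limit)

Compound 3 stands at the weak end of the series. In a functional assay on Jurkat cells (Homo sapiens) for antiproliferative activity, read by MTT assay (on this read-out lower numbers stand for stronger inhibition and higher numbers for weaker inhibition), compound 3 returns only a limit of the assay, > 50000 nM, and no number; this is the limit of > 50000 nM in this assay, at which 1 of the 3 values shown sits. The steps from compound 1 to compound 3 and from compound 2 to compound 3 are both beyond the scatter, so compound 3 is the weakest of the three shown.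

The next compound, compound 4 `COc1cc2c(cc1OC)C(=O)/C(=C/c1ccc(N)cc1)CC2`, differs from compound 3 by amino in place of methoxy on an aromatic carbon. For the measured compounds named here, none of the measured steps covers an amino group. The step of a 3.4-fold higher number from compound 1 to compound 2 (0.53 log units; beyond the scatter) concerns methyl against methoxy on the 3-substituted ring; the steps of an at least 10-fold higher number from compound 1 to compound 3 (1.00 log units; beyond the scatter) and an at least 2.9-fold higher number from compound 2 to compound 3 (0.46 log units; beyond the scatter) concern the shift from 3-methoxyphenyl or 3-methylphenyl to 4-methoxyphenyl. The data give no guide to what amino does on the 4-substituted ring, so the expected step of an at least 1.6-fold lower number from compound 3 to compound 4 (0.22 log units; that floor lies within the scatter) in this assay is set close to no change, with wide bounds because compound 3 itself sits at > 50000 nM and the true value may be well beyond it. Compound 4 is therefore estimated at 30000 nM, with a range from 5000 nM to 150000 nM, and a fair chance that only a limit is reported again.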

Compound 4, half-maximal inhibitory concentration: 40000 nM
Compound 4: the middle estimate sits 1.3-fold (0.12 log units) below what was measured; the range from low to high includes it.
By their numbers in this assay, from the lowest: compound 1; then compound 2; then compound 4. At a limit, above all of these: compound 3.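

In this assay, amino in place of methoxy, on an aromatic carbon para to a large group, moves this position from a limit to a measured number, with an at least 1.2-fold lower number from compound 3 to compound 4 (0.09 log units; that floor lies within the scatter). That step is only a floor, and its true size stays open because compound 3 stands at a limit: the limit of > 50000 nM in this assay, at which 1 of the 4 values shown sits.

The 4-aminophenyl group still falls short of both groups it can be set against, with a 2.4-fold higher number from compound 2 to compound 4 (0.37 log units; beyond the scatter) and an 8.0-fold higher number from compound 1 to compound 4 (0.90 log units; beyond the scatter), so among these four compounds the 3-methoxyphenyl and 3-methylphenyl groups give the lower numbers, and neither 4-substituted phenyl matches them.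

The compounds shown leave open whether the higher numbers follow the position or only the two groups tried there, a question that 3-aminophenyl, or a carboxylic acid or fluorine on the same aromatic carbon, would bear on. They also leave open whether a larger amine, such as dimethylamino, would keep, lower or raise the number given by amino at this position.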